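Antiproliferative Activity of Uracil Diol Side-Chain Analogues

This account rests on a few compounds, and the source may have more. Where it says the series, first, only, none or still open, it means among the compounds named here.

Measured compounds:
compound 1, `O=c1[nH]c(=O)n(CCC(CO)CO)cc1-c1ccco1`, 500 nM
compound 2, `CCCCCc1ccc(C#Cc2cn(CCC(COC(C)=O)COC(C)=O)c(=O)n(C(=O)c3ccccc3)c2=O)cc1`, 17600 nM
compound 3, `O=c1[nH]c(=O)n(CCC(CO)CO)cc1C#Cc1cc(F)cc(F)c1`, > 100000 nM

The three compounds were examined in an ADME assay on BJ cells (Homo sapiens) for antiproliferative activity, read by MTT assay, with a stated time of 72 h; a higher number here means a weaker inhibitor, a lower number a stronger inhibitor. Compound 1 gives 500 nM in this assay, and compound 2 gives 17600 nM; no single-point change connects these two, so their values are reported side by side without a step between them. Compound 3 stands apart: in this assay it returns only a limit, > 100000 nM, so its true value is not known as a number. It sits at the limit of > 100000 nM in this assay, at which 1 of the 3 values shown sits, the weaker end of what the assay reports.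

The next compound, compound 4, is `O=c1[nH]c(=O)n(CCC(CO)CO)cc1C#CCc1ccccc1`. It differs from compound 3 by benzyl in place of 3,5-difluorophenyl on a triple-bonded carbon. Since compound 3 is known only as a limit, the size of the step cannot be anchored to a measured number, and no comparable change among the measured compounds exists to guide it. The expectation is that compound 4 remains weak, at or near the limit, with any shift being toward a somewhat stronger inhibitor; the expected step is an at least 2.0-fold lower number from compound 3 to compound 4 (0.30 log units; that floor lies within the scatter). Compound 4 is therefore estimated at 50000 nM in this assay, with a range from 5000 nM to 200000 nM, and a substantial chance that only a limit is again reported.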

Compound 4, half-maximal inhibitory concentration: > 100000 nM
Compound 4 was reported as a limit; the forecaster's own chance of this, stated with the estimate: 45%; at least 2.0-fold (0.30 log units) between middle value and limit.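

Compound 3 and compound 4 both return only a limit in this assay, so no step can be read from compound 3 to compound 4: the limit of > 100000 nM in this assay, at which 2 of the 4 values shown sit.

The compounds shown leave open how benzyl and 3,5-difluorophenyl on a triple-bonded carbon compare in this assay, and how far the true values of compound 3 and compound 4 lie from that limit.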